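This account rests on a few compounds, and the source may have more. Where it says the series, first, only, none or still open, it means among the compounds named here.

Measured so far:
- compound 1, `O=C(CCc1cccc2c1B(O)OC2)Nc1ccccc1`: 30000 nM
- compound 2, `O=C(CCc1cccc2c1B(O)OC2)Nc1ccc(Br)cc1`: 42000 nM

In an ADME assay on WI-38 cells (Homo sapiens) for cytotoxicity, read by MTT assay, with a stated time of 72 h (on this read-out lower numbers stand for stronger inhibition and higher numbers for weaker inhibition), compound 1 gives 30000 nM, and compound 2 gives 42000 nM. Within the data shown here, compound 2 holds the larger of the two numbers, but the only step between them, a 1.4-fold higher number from compound 1 to compound 2 (0.15 log units; within the scatter), is within the scatter, so the two compounds cannot be told apart on cytotoxicity.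

Compound 3, `O=C(CCc1cccc2c1B(O)OC2)Nc1cccc(Br)c1`, is the next compound. It differs from compound 2 by 3-bromophenyl in place of 4-bromophenyl on an amide-type nitrogen.

Among the measured compounds shown here, the single measured step, a 1.4-fold higher number from compound 1 to compound 2 (0.15 log units; within the scatter), concerns adding a bromine rather than moving one, so it bears only loosely on this change; it does show that a bromine on that ring left the number essentially unchanged. No step beyond the scatter is therefore expected, and the estimated step is a 1.1-fold lower number from compound 2 to compound 3 (0.02 log units; within the scatter). Compound 3 is estimated at 40000 nM, with a range from 20000 nM to 80000 nM.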

Compound 3, half-maximal inhibitory concentration: 20000 nM
The estimate for compound 3 lay 2.0-fold (0.30 log units) above the measured number; the measured number falls inside the stated range.
By their numbers in this assay, from the lowest: compounds 3, 1 and 2 (each within the scatter of the next, the first and the last beyond it).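

Where the bromine sits on the ring matters more here than whether a bromine is present at all. In this assay, among these compounds, 3-bromophenyl in place of 4-bromophenyl on the amide-type nitrogen gives the first step beyond the scatter, though only a modest one (a 2.1-fold lower number from compound 2 to compound 3 (0.32 log units; beyond the scatter)). Set against the unsubstituted ring, however, the 3-bromophenyl change stays within the scatter (a 1.5-fold lower number from compound 1 to compound 3 (0.18 log units; within the scatter)), so only the two brominated compounds can be told apart, and nothing available explains the difference between them.

A step this close to the scatter rests on just one pair of compounds, so it may not hold for other groups. Going by these compounds, whether a chlorine, a methoxy group or an amine on that ring would separate in the same way remains open, as does the effect of a longer chain in the linker to the shared core.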